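Amino in place of methoxy on a carbonyl carbon

This account rests on a few compounds, and the source may have more. Where it says the series, first, only, none or still open, it means among the compounds named here.

For the measured compounds named here, compound 2, with the structure `COC(=O)c1cccc(NC(=O)c2cc3cc([N+](=O)[O-])ccc3s2)c1`, gives 25 ug/mL in a physicochemical assay for solubility (on this read-out higher numbers stand for higher solubility and lower numbers for lower solubility), the only value reported as a number among the two measured compounds. Compound 1, with the structure `NC(=O)c1cccc(NC(=O)c2cc3ccccc3s2)c1`, is reported only at a limit, < 5 ug/mL in this assay, so the measurement gives no number for it; this is the limit of < 5 ug/mL in this assay, at which 1 of the 2 values shown sits. Compound 3, with the structure `NC(=O)c1cccc(NC(=O)c2cc3cc([N+](=O)[O-])ccc3s2)c1`, has not yet been measured in this assay. It differs from compound 2 by amino in place of methoxy on a carbonyl carbon. Going by the values given here, no measured pair shows this change, and the two values at hand do not settle its direction. The step of a 3.1-fold lower number from compound 2 to compound 3 (0.49 log units; beyond the scatter) is expected to be a decrease that is likely beyond the scatter. Compound 3 is estimated at 8 ug/mL, within a range from 3 ug/mL to 25 ug/mL in this assay.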

Compound 3, solubility: 25 ug/mL
Compound 3: middle estimate off by 3.1-fold (0.49 log units), on the low side; measured number inside the range.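

In this assay, the change from methoxycarbonyl to carbamoyl, read on the nitro-bearing core, gives no change at the digits printed from compound 2 to compound 3 (within the scatter), so amino in place of methoxy on this carbonyl carbon does not separate the two compounds. For the compounds shown here, with the carbamoyl held fixed, the first measured comparison at the aromatic carbon, nitro in place of hydrogen, gives an at least 5.0-fold higher number from compound 1 to compound 3 (0.69 log units; beyond the scatter). The compound 1 end of that step is a limit and not a number, so the step has a lower bound only: the limit of < 5 ug/mL in this assay, at which 1 of the 3 values shown sits.

As far as these compounds go, the true size of the nitro step remains open, as does whether the methoxy-to-amino change would read the same on the core without nitro. The compounds shown also leave open where a carboxylic acid or an N-methyl amide on this carbonyl carbon would stand in this assay.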